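This account rests on a few compounds, and the source may have more. Where it says the series, first, only, none or still open, it means among the compounds named here.

Measured so far:
- compound 1, `COc1ccc(S(=O)(=O)NCCN2CCC(CCC(=O)c3cc(Cl)c(N)cc3OC)CC2)cc1Cl`, in an assay on HEK293 cells for displacement of a labelled ligand from 5-hydroxytryptamine receptor 6 (Homo sapiens), with a stated time of 60 min, tested at 0.01 uM, in the presence of a further agent that is not named here (a lower number here means a weaker effect, a higher number a stronger effect of the compound at the concentration tested), gives 20%
- compound 2, `COc1cc(N)c(Cl)cc1C(=O)CCC1CCN(CCNS(=O)(=O)c2ccc3c(c2)NC(=O)CO3)CC1`, in this assay gives "not active" (no number reported)

Compound 2 stands without a single number: in this assay it is reported only as "not active" (no number reported), so no figure can be placed against it. Compound 1 gives a modest effect of 20% in this assay, and the two results are shown side by side without a computed step between them.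

Compound 3, `COc1ccc(S(=O)(=O)NCCN2CCC(CCC(=O)c3cc(Cl)c(N)cc3OC)CC2)cc1`, is the next compound to be tested in this assay. It differs from compound 2 in one place: a group of 8 heavy atoms (7 carbon, 1 oxygen; one six-membered aromatic ring of carbon only) in place of a group of 11 heavy atoms (8 carbon, 1 nitrogen, 2 oxygen; one six-membered non-aromatic ring with 2 hetero atoms, one six-membered aromatic ring of carbon only), on a sulfonyl sulfur. For the measured compounds named here, no step between measured compounds is available, so the size of the change cannot be read from an earlier pair. Given that compound 1, which also carries a methoxyphenyl on the sulfonyl sulfur, gives 20%, a small effect of similar size is expected for compound 3 rather than a large one. Compound 3 is estimated at 15% in this assay, within a range of 0% to 35%.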

Compound 3, a percentage reported as inhibition, at one concentration (the size of the read-out at that concentration, not a potency): 36%
Compound 3: the middle estimate sits 21 percentage points below what was measured; the measured number lies above the stated range.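

In this assay, for the compounds shown here, hydrogen in place of chloro on an aromatic carbon of the ring on the sulfonyl sulfur gives a number 16 percentage points higher from compound 1 to compound 3 (beyond the scatter), the first change whose size can be read. At this position, then, the chloro is not required for the effect at the tested concentration, and the compound without it reads higher. Compound 2 has no number, so its change to the 4-methoxyphenyl of compound 3 cannot be read as a step, and nothing measured here accounts for the rise from chloro to hydrogen.

Going by these compounds, whether the rise is specific to losing chloro stays open, since a fluoro or a methyl on that aromatic carbon would be needed to tell. On these data alone, it is also open how a group such as an amine in place of the methoxy would compare with compound 3.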